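Series notes: compound 3 to compound 4

A few compounds are considered here, and "the series" means these few. Any claim that something is new, unique, unknown or untested is made for them only; others in the source may bear on it.

In a functional assay on HCT-116 cells (Homo sapiens) for antiproliferative activity, read by sulforhodamine B assay, with a stated time of 72 h (on this read-out lower numbers stand for stronger inhibition and higher numbers for weaker inhibition), compound 3 `CSc1ccc(Nc2ncnc3c2ncn3[C@@H]2O[C@H](CO)[C@@H](O)[C@H]2O)cc1` gives only a limit, > 100000 nM, and no number. Compound 1 `Cc1ccc(N2CCN(c3ncnc4c3ncn4[C@@H]3O[C@H](CO)[C@@H](O)[C@H]3O)CC2)cc1` reads 70000 nM and compound 2 `Nc1nc(N2CCN(c3ccc(F)cc3)CC2)c2ncn([C@@H]3O[C@H](CO)[C@@H](O)[C@H]3O)c2n1` reads 30000 nM. Compound 4 `OC[C@H]1O[C@@H](n2cnc3c(NCCNc4ccccc4)ncnc32)[C@H](O)[C@@H]1O` carries 2-anilinoethyl in place of 4-(methylsulfanyl)phenyl on a nitrogen on an aromatic ring. For the measured compounds named here, no measured pair differs in one place only, so no direct guide to this change exists in this assay. Weak inhibition is still expected, with compound 1 at 70000 nM as the reference value. The expected at least 1.4-fold lower number from compound 3 to compound 4 (0.15 log units; that floor lies within the scatter) is small, toward stronger inhibition if anything, and probably no larger than the scatter. For compound 4 the estimated value is 70000 nM, with an expected range of 25000 nM to 100000 nM.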

Compound 4, half-maximal inhibitory concentration: 30000 nM
The estimate for compound 4 lay 2.3-fold (0.37 log units) above the measured number; measured number inside the range.
By their numbers in this assay, from the lowest: compounds 2 and 4 (each within the scatter of the next); then compound 1. At a limit, above all of these: compound 3.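

In this assay, 2-anilinoethyl in place of 4-(methylsulfanyl)phenyl on a nitrogen on an aromatic ring gives an at least 3.3-fold lower number from compound 3 to compound 4 (0.52 log units; beyond the scatter). This size is only a floor, because compound 3 gives a limit and no number: the limit of > 100000 nM in this assay, at which 1 of the 4 values shown sits. Both groups hold one six-membered aromatic ring of carbon only, so the step goes with the remaining differences, the added chain nitrogen and the lost sulfur, which stay unseparated here. Going by these compounds, the full size of the step remains open. So does the effect of a longer chain, or of a carboxylic acid in place of the anilino group.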